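The compounds below may be only part of what the source reports. "The series", "measured", "known", "first", "only" and "open" are said of these compounds alone.

Measured in a functional assay on HCT-116 cells (Homo sapiens) for inhibition, read by MTT assay, with a stated time of 48 h; a lower number here means a stronger inhibitor, a higher number a weaker inhibitor:
- compound 1 `COc1ccc(CSc2nnc(-c3cc(OC)c(OC)c(OC)c3)n2-c2ccc(OC)cc2)cc1`: 49600 nM
- compound 2 `COc1cc(-c2nnc(SC)n2-c2ccc(N(C)C)cc2)cc(OC)c1OC`: > 60000 nM, a limit
- compound 3 `CCSc1nnc(-c2cc(OC)c(OC)c(OC)c2)n1-c1ccc(N(C)C)cc1`: > 60000 nM, a limit

Compound 3 has no number, only a limit of > 60000 nM. Compound 4 `COc1ccc(CSc2nnc(-c3cc(OC)c(OC)c(OC)c3)n2-c2ccc(N(C)C)cc2)cc1` differs from it by 4-methoxyphenyl in place of methyl on a saturated chain carbon bound to a sulfur, with 4-methoxyphenyl in place of methyl on a saturated chain carbon bound to a sulfur, so ethylsulfanyl becomes (4-methoxybenzyl)sulfanyl. Among the measured compounds shown here, the only measured step at this place is a step that the two limits leave unreadable from compound 2 to compound 3, and it offers no size to carry over. Compound 1 carries the same (4-methoxybenzyl)sulfanyl group and gives a number, 49600 nM, so some gain in this assay is expected. The expected change, of loosely known size, is an at least 2.4-fold lower number from compound 3 to compound 4 (0.38 log units; beyond the scatter). For compound 4 the estimated value is 25000 nM, with an expected range of 4000 nM to 60000 nM.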

Compound 4, half-maximal inhibitory concentration: 1150 nM
Beside the measured number, compound 4's estimate is 22-fold (1.34 log units) above it; measured number outside the range, below it.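

In this assay, the (4-methoxybenzyl)sulfanyl group gives an at least 52-fold lower number from compound 3 to compound 4 (1.71 log units; beyond the scatter) and an at least 52-fold lower number from compound 2 to compound 4 (1.71 log units; beyond the scatter), so a large change at this place on the saturated chain carbon bound to a sulfur is now visible. Neither group alone accounts for compound 4, since dimethylamino in place of methoxy on an aromatic carbon gives a 43-fold lower number from compound 1 to compound 4 (1.63 log units; beyond the scatter). The step from compound 2 to compound 3 cannot be read, both values being limits: the limit of > 60000 nM in this assay, at which 2 of the 4 values shown sit.

Going by these compounds, whether an unsubstituted benzyl or a longer chain on the sulfur would give a similar step remains open. So does whether an amine other than dimethylamino would serve on the aromatic ring.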